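Does a new sulfonyl group move clearance?

The compounds below may be only part of what the source reports. "The series", "measured", "known", "first", "only" and "open" are said of these compounds alone.

In an ADME assay on microsomes from liver (Homo sapiens) for pharmacokinetics, read by LC-MS, with a stated time of 60 min, tested at 1 uM (a higher number here means faster removal of the compound, a lower number slower removal), compound 1 (`O=C(NCc1ccc(S(=O)(=O)c2ccccc2)cc1)N1Cc2ccncc2C1`) gives 7.5 mL/min/kg and compound 2 (`O=C(NCc1ccc(S(=O)(=O)C2CCCOC2)cc1)N1Cc2ccncc2C1`) gives 7 mL/min/kg. These two numbers lie within the scatter of each other, so compound 2 stands level with compound 1. Compound 3 (`CN1CCC(S(=O)(=O)c2ccc(CNC(=O)N3Cc4ccncc4C3)cc2)CC1`) keeps the shared core and differs only on the sulfonyl sulfur, where 1-methylpiperidin-4-yl sits in place of oxan-3-yl: 1-methylpiperidin-4-yl in place of oxan-3-yl on a sulfonyl sulfur. For the measured compounds named here, one measured step bears on this spot, the one with oxan-3-yl in place of phenyl: a 1.1-fold lower number from compound 1 to compound 2 (0.03 log units; within the scatter), which is within the scatter. Going by the values given here, that is thin evidence, and no measured compound carries the entering group, so the range must stay wide. No shift beyond the scatter is expected in this assay. The expected step is a 1.1-fold higher number from compound 2 to compound 3 (0.06 log units; within the scatter). The estimate for compound 3 is 8 mL/min/kg, with a range of 4.5 mL/min/kg to 16 mL/min/kg.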

Compound 3, clearance: 11 mL/min/kg
For compound 3 the middle estimate is 1.4-fold (0.14 log units) below the measured one; the range from low to high includes it.
By their numbers in this assay, from the lowest: compounds 2, 1 and 3 (each within the scatter of the next).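

In this assay, for the compounds shown here, the sulfonyl sulfur now carries a third kind of ring, and the first step to it is a 1.6-fold higher number from compound 2 to compound 3 (0.20 log units; within the scatter) while the second is a 1.5-fold higher number from compound 1 to compound 3 (0.17 log units; within the scatter) so neither step leaves the scatter. Compound 1, compound 2 and compound 3 therefore stand level in this read-out, and this place has now taken a ring with a nitrogen and a methyl group as well as phenyl and oxan-3-yl without a clear shift. Nothing measured here offers an explanation for this result.

From the compounds shown here alone, all three groups are six-membered rings, so a carboxylic acid or a longer open chain on the sulfonyl sulfur remains untested in this comparison. Whether the methyl on the piperidine matters also stays open, as a piperidin-4-yl with a free amine is not among these compounds.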